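Anilinoquinazoline series: ester-to-methoxypyridine swap at the aniline

This account rests on a few compounds, and the source may have more. Where it says the series, first, only, none or still open, it means among the compounds named here.

Measured compounds in a functional assay on A549 cells (Homo sapiens) for cytotoxicity, read by sulforhodamine B assay, with a stated time of 72 h; on this read-out lower numbers stand for stronger inhibition and higher numbers for weaker inhibition:
- compound 1 `CCS(=O)(=O)Nc1cc(-c2ccc3ncnc(Nc4cccc(F)c4)c3c2)cnc1OC` gives 9940 nM
- compound 2 `CCS(=O)(=O)Nc1cc(-c2ccc3ncnc(Nc4ccc(OC)c(Cl)c4)c3c2)cnc1OC` gives 5240 nM
- compound 3 `CCS(=O)(=O)Nc1cc(-c2ccc3ncnc(Nc4cccc(C(=O)OC)c4)c3c2)cnc1OC` gives 1100 nM

Compound 3 stands at the lowest number of the three. Its nearest neighbour is compound 2, with the step of a 4.8-fold lower number from compound 2 to compound 3 (0.68 log units; beyond the scatter), and the furthest is compound 1, with the step of a 9.0-fold lower number from compound 1 to compound 3 (0.96 log units; beyond the scatter). Between compound 1 and compound 2 the step of a 1.9-fold lower number from compound 1 to compound 2 (0.28 log units; within the scatter) is within the scatter.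

Compound 4 `CCS(=O)(=O)Nc1cc(-c2ccc3ncnc(Nc4ccc(OC)nc4)c3c2)cnc1OC` differs from compound 3 by 6-methoxypyridin-3-yl in place of 3-(methoxycarbonyl)phenyl on a nitrogen on an aromatic ring. For the measured compounds named here, no measured step exchanges the ester for a methoxypyridine directly. Going by the values given here, the steps that bear on it show that the methoxycarbonyl-bearing aniline stands apart from both the fluorophenyl and the chloro-methoxyphenyl, since a 9.0-fold lower number from compound 1 to compound 3 (0.96 log units; beyond the scatter) and a 4.8-fold lower number from compound 2 to compound 3 (0.68 log units; beyond the scatter) are both beyond the scatter, while the two non-ester anilines sit close together. Removing the ester in compound 4 is therefore expected to move the number back toward those of compound 1 and compound 2, a step of a 5.5-fold higher number from compound 3 to compound 4 (0.74 log units; beyond the scatter) in this assay. The estimate for compound 4 is 6000 nM, with a range of 2000 nM to 20000 nM.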

Compound 4, half-maximal inhibitory concentration: 5560 nM
Compound 4: middle estimate off by 1.1-fold (0.03 log units), on the high side, within the range that was stated.
By their numbers in this assay, from the lowest: compound 3; then compounds 2, 4 and 1 (each within the scatter of the next).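

In this assay the exchange of 3-(methoxycarbonyl)phenyl for 6-methoxypyridin-3-yl on the aniline nitrogen gives a 5.1-fold higher number from compound 3 to compound 4 (0.70 log units; beyond the scatter) and so does not keep the lower number of the ester compound. The new group also cannot be told apart from the two earlier non-ester groups, with a 1.1-fold higher number from compound 2 to compound 4 (0.03 log units; within the scatter) and a 1.8-fold lower number from compound 1 to compound 4 (0.25 log units; within the scatter) both within the scatter, so that across three different non-ester groups, one of them on a pyridine ring, only compound 3 stands apart, and none of the four compounds goes against this. Nothing available explains the separation of compound 3 from the others.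

Open, as far as these compounds go, is whether the whole methoxycarbonyl group is needed, or whether a carboxylic acid, a primary amide or an acetyl group in its place would give a similar number. Also open, from the compounds shown here alone, is whether a methoxycarbonyl group on the pyridine ring would do the same.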